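The compounds below may be only part of what the source reports. "The series", "measured", "known", "first", "only" and "open" are said of these compounds alone.

In a toxicity assay on MT4 cells (Homo sapiens) for cytotoxicity, read by MTT assay, with a stated time of 5 days (a higher number here means that more compound is tolerated, a lower number that less compound is tolerated), compound 1 `Cc1cnc(Nc2ccc(C#N)cc2)nc1Nc1c(F)cc(-c2cccnc2)cc1F` gives 1100 nM and compound 2 `Cc1cnc(Nc2ccc(C#N)cc2)nc1Nc1c(F)cc(-c2cncnc2)cc1F` gives 900 nM. These two sit together at the low end of the three numbers in hand, the step being a 1.2-fold lower number from compound 1 to compound 2 (0.09 log units; within the scatter). Compound 3 `Cc1cnc(Nc2ccc(C#N)cc2)nc1Nc1c(F)cc(-c2ccsc2)cc1F` stands far off at 261000 nM, with a 290-fold higher number from compound 2 to compound 3 (2.46 log units; beyond the scatter) and a 240-fold higher number from compound 1 to compound 3 (2.38 log units; beyond the scatter).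

Compound 4 `Cc1cnc(Nc2ccc(C#N)cc2)nc1Nc1c(F)cc(-c2cc(F)nc(F)c2)cc1F` carries a new group on the same aromatic carbon: 2,6-difluoropyridin-4-yl in place of pyrimidin-5-yl on an aromatic carbon. For the measured compounds named here, two measured steps bear on this. Pyridin-3-yl and pyrimidin-5-yl are interchangeable here, with a 1.2-fold lower number from compound 1 to compound 2 (0.09 log units; within the scatter), while thiophen-3-yl in compound 3 shows how far the number can move, with a 290-fold higher number from compound 2 to compound 3 (2.46 log units; beyond the scatter). No fluorinated ring at this place has been measured, so the guidance is loose. A rise beyond the scatter is expected in this assay, though well short of the thiophen-3-yl step.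

The expected step is a 10-fold higher number from compound 2 to compound 4 (1.00 log units; beyond the scatter). The estimated value for compound 4 is 9000 nM, within an expected range of 1000 nM to 100000 nM.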

Compound 4, half-maximal cytotoxic concentration: 103000 nM
Compound 4: middle estimate off by 11-fold (1.06 log units), on the low side; measured number above the stated range.
By their numbers in this assay, from the lowest: compounds 2 and 1 (each within the scatter of the next); then compound 4; then compound 3.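

In this assay, a six-membered aromatic ring with ring nitrogen does not by itself keep the number low at this place: with 2,6-difluoropyridin-4-yl entering, the steps are a 110-fold higher number from compound 2 to compound 4 (2.06 log units; beyond the scatter) and a 94-fold higher number from compound 1 to compound 4 (1.97 log units; beyond the scatter), a shift that pyrimidin-5-yl in place of pyridin-3-yl did not hint at. The same group still gives a 2.5-fold lower number from compound 3 to compound 4 (0.40 log units; beyond the scatter), so high numbers at this place are not confined to thiophen-3-yl, and two quite different rings now reach that end of the range. Nothing in hand explains why these groups part so widely from the other two.

The compounds shown leave open whether the two fluorines or the change in ring hetero atoms carries the rise, which plain pyridin-4-yl would help to separate. On these data alone, how an amine or a methoxy group on the same pyridine ring would read also stays open.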